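The compounds below may be only part of what the source reports. "The series", "measured", "known", "first", "only" and "open" are said of these compounds alone.

Of the compounds shown here, three built on one shared core have been tested in an assay on Sf9 cells for inhibition of protein deacetylase HDAC6 (Homo sapiens), read by fluorescence, with a stated time of 40 min, tested at 100 nM; on this read-out higher numbers stand for more inhibition at the one concentration tested (going by the name of the read-out) and lower numbers for less inhibition. Compound 1 `COc1ccc(-c2nc(CNc3ccc(C(=O)NO)cc3)n(-c3ccccc3)n2)cc1` carries a methoxyphenyl group and gives 77.6%. Compound 2 `O=C(NO)c1ccc(NCc2nc(-c3ccc(Br)cc3)nn2-c2ccccc2)cc1` carries a bromophenyl group in that place and gives 54.7%. Compound 3 `O=C(NO)c1ccc(NCc2nc(-c3ccc(F)cc3)nn2-c2ccccc2)cc1` carries a fluorophenyl group there and gives 70.9%. On these numbers compound 3 stands above compound 2, the step being a number 16.2 percentage points higher from compound 2 to compound 3 (beyond the scatter), whereas compound 3 and compound 1 lie within the scatter of each other, as the step of a number 6.7 percentage points lower from compound 1 to compound 3 (within the scatter) shows. Compound 1 and compound 2 are separated by a number 22.9 percentage points lower from compound 1 to compound 2 (beyond the scatter).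

Compound 4 `O=C(NO)c1ccc(NCc2nc(-c3ccc(Cl)c(Cl)c3)nn2-c2ccccc2)cc1` has not yet been measured. It differs from compound 3 in a single place: 3,4-dichlorophenyl in place of 4-fluorophenyl on an aromatic carbon. The step that bears most directly on this change is the one from the bromophenyl of compound 2 to the fluorophenyl of compound 3, a modest gain beyond the scatter; the step from compound 1 to compound 2 points the same way, while the fluoro-for-methoxy step stays within the scatter. With fluorine leaving and two chlorines entering, a modest fall is expected, in line with the drop seen in compound 2, though the exact size is uncertain because only a number 16.2 percentage points higher from compound 2 to compound 3 (beyond the scatter) compares two halogens. Compound 4 is therefore estimated at 58%, with a range from 40% to 75%, which is an expected step of a number 12.9 percentage points lower from compound 3 to compound 4 (beyond the scatter).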

Compound 4, a percentage reported as inhibition, at one concentration (the size of the read-out at that concentration, not a potency): 34.5%
Estimate against measurement, compound 4: 23.5 percentage points above; the whole stated range lies above it.
By their numbers in this assay, from the lowest: compound 4; then compound 2; then compounds 3 and 1 (each within the scatter of the next).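

Across this assay, this position on the shared core can carry the read-out much lower than the first three compounds suggested, with a number 36.4 percentage points lower from compound 3 to compound 4 (beyond the scatter) and a number 20.2 percentage points lower from compound 2 to compound 4 (beyond the scatter) and also a number 43.1 percentage points lower from compound 1 to compound 4 (beyond the scatter). Each earlier compound has one group on this phenyl ring, and the largest step among them is a number 22.9 percentage points lower from compound 1 to compound 2 (beyond the scatter), so 3,4-dichlorophenyl, the only pattern here with two ring groups, marks compound 4 as the lowest of the four. Nothing available explains this fall.

The change from 4-fluorophenyl to 3,4-dichlorophenyl swaps the kind of halogen and adds a second one at once, so these compounds cannot show whether the fall comes from chlorine itself, from the second group or from the two together; a phenyl ring bearing a single chlorine, as in 4-chlorophenyl or 3-chlorophenyl, would separate these possibilities. As far as these compounds go, how this position responds to quite different groups on the same ring, such as an amine or a carboxylic acid, also remains open.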